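Cytotoxicity at the limit: an unmeasured side-chain swap

The source may report more compounds than this note shows. Statements on the series, on what has been measured and on what is new or still open speak of the compounds shown alone.

Compound 1 `Fc1cccc(F)c1Cn1cccc2nc(-c3c(F)cccc3F)nc1-2` reaches only the assay limit, > 100000 nM, in an ADME assay on MDBK cells (Bos taurus) for cytotoxicity; a lower number here means that less compound is tolerated, a higher number that more compound is tolerated.
Compound 2 `Fc1cccc(F)c1-c1nc2ccn(Cc3ccccc3)cc-2n1` likewise gives only a limit, > 100000 nM, in this assay.
Compound 3 `Cc1cccc(Cn2ccc3nc(-c4ccccc4)nc-3c2)c1` also gives only a limit, > 100000 nM, in this assay.

So compound 3 stands where every value shown stands: at the limit of > 100000 nM in this assay, at which 3 of the 3 values shown sit, with no number below the limit for any of the three. Compound 4 `c1ccc(CCCn2ccc3nc(-c4ccccc4)nc-3c2)cc1` has not yet been measured. It differs from compound 3 in one place: phenethyl in place of 3-methylphenyl on a saturated chain carbon bound to an aromatic nitrogen. Among the compounds with values here, no step between two measured compounds is known, so no direction can be read from the data. Compound 4 is expected to sit at about 100000 nM, in the range 50000 nM to 300000 nM. The expected step of a number no higher from compound 3 to compound 4 (the limit leaves the size open) is therefore none beyond the scatter.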

Compound 4, half-maximal cytotoxic concentration: > 100000 nM
Compound 4: no number, only a limit; the forecaster's own chance of this, stated with the estimate: 85%; the middle value lies on the limit itself.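

Compound 3 and compound 4 each give only a limit in this assay, so no step between them can be read: the limit of > 100000 nM in this assay, at which 4 of the 4 values shown sit.

The compounds shown leave open what real value lies behind each limit, and so whether phenethyl and 3-methylphenyl differ at all.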